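This account rests on a few compounds, and the source may have more. Where it says the series, first, only, none or still open, it means among the compounds named here.

Measured compounds:
Compound 1 `FC(F)(F)c1ccc(CSc2nc(Nc3ccccc3C(F)(F)F)c3ccccc3n2)cc1` — in a functional assay on MGC-803 cells (Homo sapiens) for cytotoxicity, read by MTT assay, with a stated time of 72 h (on this read-out lower numbers stand for stronger inhibition and higher numbers for weaker inhibition), compound 1 gives > 50000 nM, a limit of the assay.
Compound 2 `FC(F)(F)c1ccc(CSc2nc(Nc3ccccc3Cl)c3ccccc3n2)cc1` — in this assay compound 2 gives > 50000 nM, a limit of the assay.
Compound 3 `COc1ccccc1Nc1nc(SCc2ccc(C(F)(F)F)cc2)nc2ccccc12` — in this assay compound 3 gives > 50000 nM, a limit of the assay.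

Compound 3 thus stands only at a limit, as do the other two measured compounds. The steps a step that the two limits leave unreadable from compound 1 to compound 2, a step that the two limits leave unreadable from compound 1 to compound 3 and a step that the two limits leave unreadable from compound 2 to compound 3 are all unreadable since (the limit of > 50000 nM in this assay, at which 3 of the 3 values shown sit). Compound 4 `COc1cc(Nc2nc(SCc3ccc(C(F)(F)F)cc3)nc3ccccc23)cc(OC)c1` differs from compound 3 by 3,5-dimethoxyphenyl in place of 2-methoxyphenyl on a nitrogen on an aromatic ring. Within the data shown here, no measured step touches this change, and none of the measured steps sets a size. Compound 4 is estimated to remain near the same limit, with the step of an at least 1.1-fold lower number from compound 3 to compound 4 (0.04 log units; that floor lies within the scatter) expected to be small or unreadable. Compound 4 is therefore estimated at 45000 nM, within 12000 nM to 120000 nM.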

Compound 4, half-maximal inhibitory concentration: 8580 nM
For compound 4 the middle estimate is 5.2-fold (0.72 log units) above the measured one; measured number outside the range, below it.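

Among these compounds, at this place, on a nitrogen on an aromatic ring, 3,5-dimethoxyphenyl gives the only readable value in this assay, with an at least 5.8-fold lower number from compound 3 to compound 4 (0.76 log units; beyond the scatter). The same holds against the other two groups, with an at least 5.8-fold lower number from compound 2 to compound 4 (0.76 log units; beyond the scatter) and with an at least 5.8-fold lower number from compound 1 to compound 4 (0.76 log units; beyond the scatter). These sizes are floors, and the steps among compound 1, compound 2 and compound 3 cannot be read: the limit of > 50000 nM in this assay, at which 3 of the 4 values shown sit.

The compounds shown leave open whether the methoxy groups themselves carry the change. Going by these compounds, how an amine or a carboxylic acid on this phenyl ring would read in this assay also stays open.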